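The compounds below may be only part of what the source reports. "The series", "measured", "known", "first", "only" and "open" are said of these compounds alone.

In a functional assay on SK-OV-3 cells (Homo sapiens) for inhibition, read by CCK-8 assay, with a stated time of 70 h (a lower number here means a stronger inhibitor, a higher number a weaker inhibitor), three compounds built on a shared core have been measured so far. Compound 1 `COc1ccc(OCCOCCNC2CCCC2)cc1` reads 99100 nM and compound 2 `COc1ccc(COc2ccc(OCCOCCNC3CCCC3)cc2)cc1` reads 15700 nM while compound 3 `Clc1ccc(COc2ccc(OCCOCCNC3CCCC3)cc2)cc1` reads 7670 nM and is the strongest inhibitor of the three.

Compound 4 `O=C(O)c1ccccc1COc1ccc(OCCOCCNC2CCCC2)cc1` differs from compound 3 in one place. The change is 2-carboxyphenyl in place of 4-chlorophenyl on a saturated chain carbon bound to an oxygen on an aromatic ring and it puts 2-carboxyphenyl in place of 4-chlorophenyl on a saturated chain carbon bound to an oxygen on an aromatic ring.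

Among the measured compounds shown here, three measured steps bear on this. Putting 4-methoxyphenyl on that carbon gave a 6.3-fold lower number from compound 1 to compound 2 (0.80 log units; beyond the scatter) as a modest gain, and putting 4-chlorophenyl there gave a 13-fold lower number from compound 1 to compound 3 (1.11 log units; beyond the scatter) as a large one. Chloro in place of methoxy gave a 2.0-fold lower number from compound 2 to compound 3 (0.31 log units; beyond the scatter) as a modest further gain. For the measured compounds named here, no measured compound carries 2-carboxyphenyl, so the size of the new step is uncertain. Going by the values given here, the only other group tried in that place, in compound 2, leaves the number higher at 15700 nM than in compound 3, so a modest rise is expected rather than a further drop. The expected change is a 3.3-fold higher number from compound 3 to compound 4 (0.51 log units; beyond the scatter) and this estimate points toward a weaker inhibitor. The estimate for compound 4 in this assay is 25000 nM with an expected range of 8000 nM to 80000 nM around it.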

Compound 4, half-maximal inhibitory concentration: > 100000 nM
Compound 4 was reported as a limit (the forecaster's own chance of this, stated with the estimate: 10%); at least 4.0-fold (0.60 log units) between middle value and limit.
By their numbers in this assay, from the lowest: compound 3; then compound 2; then compound 1. At a limit, above all of these: compound 4.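

In this assay, among the compounds shown here, a phenyl ring on this saturated chain carbon does not by itself bring a lower number: 2-carboxyphenyl gives an at least 13-fold higher number from compound 3 to compound 4 (1.11 log units; beyond the scatter), and set against 4-methoxyphenyl it gives an at least 6.3-fold higher number from compound 2 to compound 4 (0.80 log units; beyond the scatter), so this position is far less forgiving than the gains among the earlier compounds suggested. Compound 4 is reported only as a limit of the assay, not as a number, and set against the plain hydrogen on that carbon 2-carboxyphenyl gives a number no lower from compound 1 to compound 4 (the limit leaves the size open), a step whose size cannot be read: the limit of > 100000 nM in this assay, at which 1 of the 4 values shown sits.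

The swap from 4-chlorophenyl to 2-carboxyphenyl alters both the group on the ring and where it sits, so this one step cannot show which of the two accounts for the loss. On these data alone, a 2-chlorophenyl, or a methyl ester or primary amide in place of the carboxylic acid, on the same carbon would help to separate these two changes, and how far compound 4 lies past its limit also stays open.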